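A few compounds are considered here, and "the series" means these few. Any claim that something is new, unique, unknown or untested is made for them only; others in the source may bear on it.

Measured so far in an ADME assay on HeLa cells (Homo sapiens) for cytotoxicity, read by ATP content, with a stated time of 3 days; a lower number here means that less compound is tolerated, a higher number that more compound is tolerated:

compound 1, `CS(=O)(=O)CCCn1c(Cn2c(=O)n(C3CC3)c3ccncc32)cc2cc(Cl)ccc21`: > 50000 nM
compound 2, `CS(=O)(=O)CCCn1c(Cn2c(=O)n(C3COC3)c3ccncc32)cc2cc(Cl)ccc21`: > 50000 nM
compound 3, `CS(=O)(=O)CCCn1c(Cn2c(=O)n(CC3CC3)c3ccncc32)cc2cc(Cl)ccc21`: > 50000 nM

In this assay compound 1 returns > 50000 nM, which is a limit of the assay and not a number. Compound 2 likewise returns > 50000 nM, again a limit. Compound 3 returns > 50000 nM, also a limit. All three values sit at the limit of > 50000 nM in this assay, at which 3 of the 3 values shown sit, so the series gives no readable number anywhere. The substituent on the aromatic nitrogen has been varied three ways, but the steps a step that the two limits leave unreadable from compound 1 to compound 2, a step that the two limits leave unreadable from compound 1 to compound 3 and a step that the two limits leave unreadable from compound 2 to compound 3 are all unreadable, each running between two limits.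

Compound 4, `CS(=O)(=O)CCCn1c(Cn2c(=O)n(CC#N)c3ccncc32)cc2cc(Cl)ccc21`, differs from compound 3 in one place: cyano in place of cyclopropyl on a saturated chain carbon bound to an aromatic nitrogen. Cut one bond further out, the change reads cyclopropylmethyl to cyanomethyl, so the group on the aromatic nitrogen is replaced once more, as in the three measured steps.

Those steps are the only ones that bear on the change, and none of them has a size. Among the compounds with values here, no direction or size can therefore be expected from them; what they do show is that every variation at this position so far has stayed at the limit. Compound 4 is expected to do the same, with an estimated step that the limit leaves unreadable from compound 3 to compound 4 from compound 3. The estimate for compound 4 in this assay is 60000 nM, within 25000 nM to 200000 nM.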

Compound 4, half-maximal cytotoxic concentration: > 50000 nM
Compound 4 gave a limit, no number; the forecaster's own chance of this, stated with the estimate: 85%; the middle value lies beyond the limit too.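

In this assay compound 4 gives > 50000 nM, a limit and not a number. Its steps from compound 1, compound 2 and compound 3 cannot be read, each running between two limits. The whole series stands at one limit: the limit of > 50000 nM in this assay, at which 4 of the 4 values shown sit. Still open, as far as these compounds go, is how far each of the four compounds lies beyond that limit, and whether any group on the aromatic nitrogen gives a readable value.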